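Methyl to hydrogen on the aryl ether, second pairing

The compounds below may be only part of what the source reports. "The series", "measured", "known", "first", "only" and "open" are said of these compounds alone.

Compound 1 `COc1cc(-c2nn(-c3cccc(NC(=O)Nc4cc(C(F)(F)F)cc(C(F)(F)F)c4)c3)cc2-c2ccncc2)ccc1Cl` gives, in a functional assay on NCI-H522 cells (Homo sapiens) for inhibition, read by sulforhodamine B assay, with a stated time of 48 h (a higher number here means a weaker inhibitor of growth, a lower number a stronger inhibitor of growth), a total growth inhibition concentration of 1800 nM. Compound 2 `O=C(Nc1cccc(-n2cc(-c3ccncc3)c(-c3ccc(Cl)c(O)c3)n2)c1)Nc1cc(C(F)(F)F)cc(C(F)(F)F)c1` differs from it by hydrogen in place of methyl on an oxygen on an aromatic ring and in this assay gives 2510 nM; the step of a 1.4-fold higher number from compound 1 to compound 2 (0.14 log units; within the scatter) is small. Compound 3 `COc1cc(-c2nn(-c3cccc(NC(=O)Nc4ccc(Cl)c(C(F)(F)F)c4)c3)cc2-c2ccncc2)ccc1Cl` carries a different urea end; the difference between the cores of compound 3 and compound 1 is not broken down here. In this assay compound 3 gives 6060 nM, the highest number of the three, with compound 2 nearest and compound 1 furthest. Compound 4 `O=C(Nc1cccc(-n2cc(-c3ccncc3)c(-c3ccc(Cl)c(O)c3)n2)c1)Nc1ccc(Cl)c(C(F)(F)F)c1` differs from compound 3 by hydrogen in place of methyl on an oxygen on an aromatic ring, the same change as that from compound 1 to compound 2. The expected step is a 1.3-fold higher number from compound 3 to compound 4 (0.12 log units; within the scatter), resting on the earlier step of a 1.4-fold higher number from compound 1 to compound 2 (0.14 log units; within the scatter). For compound 4 the expected value in this assay is 8000 nM, between 3500 nM and 18000 nM.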

Compound 4, concentration for total growth inhibition: 2500 nM
Compound 4: middle estimate off by 3.2-fold (0.51 log units), on the high side; the measured number lies below the stated range.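

The new step on methoxy to hydroxy, in the 4-chloro-3-methoxyphenyl group, is a 2.4-fold lower number from compound 3 to compound 4 (0.38 log units; beyond the scatter), and it is the larger of the two steps seen so far. In this assay the change does not carry a fixed step from one core to the other: the same change on two cores in this assay, a 1.4-fold higher number (0.14 log units; within the scatter) from compound 1 to compound 2 and a 2.4-fold lower number (0.38 log units; beyond the scatter) from compound 3 to compound 4, 3.4-fold (0.53 log units) apart, beyond the scatter of two such steps This rests on a single pair per core, so it shows that the step depends on the core in these four compounds, but it does not show why, or how the change would read on any further core.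

On these data alone, whether an amine or an ethoxy group in place of the hydroxy would follow either step remains open. Also open, as far as these compounds go, is which step a urea end bearing a nitrile would follow.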